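Swapping a substituted aryl ring for a sulfonamide-bearing one

The source may hold more compounds than are shown below. What is called first, only, known or untested is meant among the compounds shown, and "the series" means these compounds.

Compound 1 `O=C(O)Cc1sc(C(c2ccc(F)cc2)c2ccc(F)cc2)nc1-c1ccccc1`, compound 2 `N#Cc1ccc(-c2nc(C(c3ccc(F)cc3)c3ccc(F)cc3)sc2CC(=O)O)cc1` and compound 3 `N#Cc1cc(-c2nc(C(c3ccc(F)cc3)c3ccc(F)cc3)sc2CC(=O)O)ccc1F` share one core and differ only in the aromatic group attached to it. In an in vitro assay on HEK385-7 cells for displacement of a labelled ligand from prostaglandin D2 receptor 2 (Homo sapiens) (a lower number here means a stronger inhibitor, a higher number a weaker inhibitor), compound 1 gives 16 nM, compound 2 gives 150 nM and compound 3 gives 57 nM, which places compound 3 second highest of the three, between the other two. Putting a substituent on the plain phenyl ring raised the number in both measured cases: a 9.4-fold higher number from compound 1 to compound 2 (0.97 log units; beyond the scatter) and a 3.6-fold higher number from compound 1 to compound 3 (0.55 log units; beyond the scatter), while a 2.6-fold lower number from compound 2 to compound 3 (0.42 log units; beyond the scatter).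

Compound 4 `NS(=O)(=O)c1ccc(-c2nc(C(c3ccc(F)cc3)c3ccc(F)cc3)sc2CC(=O)O)cc1` has not yet been measured. It differs from compound 3 in one place: 4-sulfamoylphenyl in place of 3-cyano-4-fluorophenyl on an aromatic carbon. For the measured compounds named here, no measured step contains this exact group. The step of a 9.4-fold higher number from compound 1 to compound 2 (0.97 log units; beyond the scatter) shows that a single substituent on this ring can weaken binding markedly, and the step of a 2.6-fold lower number from compound 2 to compound 3 (0.42 log units; beyond the scatter) shows that changing the substitution pattern shifts the number only modestly. Since the 4-sulfamoylphenyl group, like the 4-cyanophenyl group of compound 2, carries one substituent, a number closer to compound 2 than to compound 1 is expected. Compound 4 is therefore estimated to give about 150 nM in this assay, within a range from 40 nM to 600 nM. The expected step is a 2.6-fold higher number from compound 3 to compound 4 (0.42 log units; beyond the scatter).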

Compound 4, half-maximal inhibitory concentration: 1500 nM
For compound 4 the middle estimate is 10-fold (1.00 log units) below the measured one; the whole stated range lies below it.
By their numbers in this assay, from the lowest: compound 1; then compound 3; then compound 2; then compound 4.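

In this assay, the identity of a single substituent on this aryl ring matters, not merely its presence: with 4-sulfamoylphenyl in place of 4-cyanophenyl, the result is a 10-fold higher number from compound 2 to compound 4 (1.00 log units; beyond the scatter) on the same ring carbon. Set against the unsubstituted phenyl ring, the sulfamoyl group gives a 94-fold higher number from compound 1 to compound 4 (1.97 log units; beyond the scatter) as the widest step among these compounds, so this position tolerates some substituents far better than others. The exchange of the 3-cyano-4-fluorophenyl group for 4-sulfamoylphenyl, a 26-fold higher number from compound 3 to compound 4 (1.42 log units; beyond the scatter) as a large step, confirms that the substituted rings do not form one narrow band of values, and nothing available here accounts for the size of these steps.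

The compounds shown leave open whether the loss belongs to the whole sulfamoyl group or to its amino part, which a methylsulfonyl group or an N-methylsulfamoyl group on the same carbon could separate. They also leave open how a carboxylic acid or a small amide at that place would compare, and whether the sulfamoyl group would give a similar number on a different carbon of the phenyl ring.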